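Bromine Added to a Series Without Measurable Potency

The compounds below may be only part of what the source reports. "The series", "measured", "known", "first", "only" and "open" are said of these compounds alone.

Of the compounds shown here, three have been tested in a functional assay on MCF7 cells (Homo sapiens) for antiproliferative activity, read by MTT assay, with a stated time of 72 h; on this read-out lower numbers stand for stronger inhibition and higher numbers for weaker inhibition. Compound 1 `C=C1CN/C(=N/c2ccccc2)S1` gives > 100000 nM in this assay, a value that is a limit of the measurement rather than a number. Compound 2 `COc1ccc(/C=C2\S/C(=N\c3ccccc3)N(C)C2=O)cc1` likewise gives > 100000 nM in this assay, again a limit. Compound 3 `S=C(Nc1ccccc1)N1C/C(=C/c2ccccc2)S/C1=N\c1ccccc1` gives > 100000 nM in this assay, also a limit. Compound 2 therefore stands where every measured compound stands: the limit of > 100000 nM in this assay, at which 3 of the 3 values shown sit. No pair of these compounds differs in only one place, so no measured step is known.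

Compound 4 `COc1ccc(/C=C2\S/C(=N\c3ccc(Br)cc3)N(C)C2=O)cc1` is not yet measured. It differs from compound 2 by bromo in place of hydrogen on an aromatic carbon. Whether such a change could move a value from beyond the limit into a measurable range cannot be read from three limits alone. The expected step is a number no higher from compound 2 to compound 4 (the limit leaves the size open), which means no change beyond the usual scatter. Compound 4 is therefore estimated at 100000 nM in this assay, within a range from 30000 nM to 300000 nM, and most likely it will itself be reported only as a limit.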

Compound 4, half-maximal inhibitory concentration: > 100000 nM
Compound 4: no number, only a limit; the forecaster's own chance of this, stated with the estimate: 75%; the middle value lies on the limit itself.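

Compound 2 and compound 4 both rest at a limit in this assay, not at a number, so no step can be read for bromo in place of hydrogen. The compounds shown leave open what change, if any, would bring a value into a measurable range.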